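A Nitro Group Added to Compound 2

The compounds below may be only part of what the source reports. "The series", "measured", "known", "first", "only" and "open" are said of these compounds alone.

Measured so far:
- Compound 1 `O=C(CCCCC1CCSS1)Nc1ccc([N+](=O)[O-])c(C(F)(F)F)c1`: 7.46%
- Compound 2 `O=C(CCCCC(S)CCS)Nc1cccc(C(F)(F)F)c1`: 1.66%

In a functional assay on Bel-7402 cells (Homo sapiens) for inhibition, read by MTT assay, with a stated time of 24 h, tested at 1 ug/mL (a higher number here means more inhibition of growth at the concentration tested, a lower number less inhibition of growth), compound 2 gives 1.66%, which lies within the usual scatter of compound 1 at 7.46%. Compound 3 `O=C(CCCCC(S)CCS)Nc1ccc([N+](=O)[O-])c(C(F)(F)F)c1` has nitro in place of hydrogen on an aromatic carbon of compound 2, ortho to a trifluoromethyl group and para to a large group (nitro in place of hydrogen on an aromatic carbon). Compound 1 at 7.46% also carries nitro, yet stays within the scatter of compound 2, so at most a small rise, not beyond the scatter, is expected in this assay. The estimated change is a number 3.3 percentage points higher from compound 2 to compound 3 (within the scatter). Compound 3 is expected at 5%, within a range of 0% to 14%.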

Compound 3, percent growth inhibition at one concentration: 0.68%
For compound 3 the middle estimate is 4.3 percentage points above the measured one; measured number inside the range.
By their numbers in this assay, from the lowest: compounds 3, 2 and 1 (each within the scatter of the next).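

In this assay, nitro in place of hydrogen on this aromatic carbon, ortho to a trifluoromethyl group, gives a number 1 percentage points lower from compound 2 to compound 3 (within the scatter), so with the open chain as well as with the ring, nitro at this position yields no difference that stands out from the scatter. Replacing the five-membered ring with 2 hetero atoms by the open group of 5 heavy atoms gives a number 6.8 percentage points lower from compound 1 to compound 3 (within the scatter), so that change cannot be told from the scatter either. Nothing available explains these numbers. On these data alone, whether another group on this carbon, such as an amine or a nitrile, would move the number beyond the scatter stays open.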